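The source may hold more compounds than are shown below. What is called first, only, known or untested is meant among the compounds shown, and "the series" means these compounds.

Compound 1, `C(=C/c1[nH]cnc2ncnc1-2)\c1ccco1`, gives 24% in a functional assay on K562 cells (Homo sapiens) for inhibition, read by thymidine incorporation, with a stated time of 48 h, tested at 10 ug/mL; on this read-out higher numbers stand for more inhibition at the one concentration tested (going by the name of the read-out) and lower numbers for less inhibition; compound 2, `C(=C/c1ncnc2c1ncn2C1CCOCC1)\c1ccco1`, gives 35%; compound 3, `C(=C/c1[nH]cnc2ncnc1-2)\c1cccs1`, gives 50%.

Compound 1 and compound 3 share one core and differ only by thiophen-2-yl in place of furan-2-yl on a double-bonded chain carbon bound to a double-bonded chain carbon; this change gave a number 26 percentage points higher from compound 1 to compound 3 (beyond the scatter). Compound 2 carries a different core, and the difference between the two cores is not broken down here. Compound 4, `C(=C/c1ncnc2c1ncn2C1CCOCC1)\c1cccs1`, stands to compound 2 as compound 3 stands to compound 1: it differs by thiophen-2-yl in place of furan-2-yl on a double-bonded chain carbon bound to a double-bonded chain carbon, the same change, made at the same place. Among the compounds shown this change occurs twice, and only once with a measured result. Resting on that single step, a number 26 percentage points higher from compound 1 to compound 3 (beyond the scatter), the expected step is a number 23 percentage points higher from compound 2 to compound 4 (beyond the scatter). Compound 4 is therefore estimated at 58%, with a likely range from 40% to 76%.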

Compound 4, a percentage reported as inhibition, at one concentration (the size of the read-out at that concentration, not a potency): 65%
For compound 4 the middle estimate is 7 percentage points below the measured one; measured number inside the range.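

In this assay, putting thiophen-2-yl in place of furan-2-yl on the core of compound 2 gave a number 30 percentage points higher from compound 2 to compound 4 (beyond the scatter). Set beside the earlier step, the change carried over from one core to the other at a similar size: the same change on two cores in this assay, a number 26 percentage points higher (beyond the scatter) from compound 1 to compound 3 and a number 30 percentage points higher (beyond the scatter) from compound 2 to compound 4, 4 percentage points apart, within the scatter of two such steps. This shows agreement on two cores only, at one concentration in one cell assay, so it does not show that the change would carry to a third core, and it does not explain why the number rises.

The compounds shown leave open what an amine or a carboxylic acid on the thiophen-2-yl would do. They also leave open how a longer chain in place of the 2-(thiophen-2-yl)ethenyl would behave.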